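Swapping the Ring at the End of a Chain

A few compounds are considered here, and "the series" means these few. Any claim that something is new, unique, unknown or untested is made for them only; others in the source may bear on it.

Of the compounds shown here, two have been measured so far in a functional assay on HT-29 cells (Homo sapiens) for inhibition, read by MTT assay, with a stated time of 3 days (a higher number here means a weaker inhibitor, a lower number a stronger inhibitor), as the basis for this comparison. Compound 1 (`COc1ccc(/C=C\c2cc(OC)c(OC)c(OC)c2)cc1OCc1ccc(Br)cc1`) gives 108000 nM there, and compound 2 (`COCOc1ccccc1/C=C/CCCOc1cc(/C=C\c2cc(OC)c(OC)c(OC)c2)ccc1OC`) gives 9600 nM as the lower of the two numbers, a gap beyond the usual scatter. That makes compound 2 the stronger inhibitor of the pair. Compound 3 (`COc1ccc(/C=C\c2cc(OC)c(OC)c(OC)c2)cc1OCCC/C=C/c1ccc(F)cc1`) is still unmeasured and differs from compound 2 in one place (4-fluorophenyl in place of 2-(methoxymethoxy)phenyl on a double-bonded chain carbon bound to a double-bonded chain carbon), with 4-fluorophenyl in place of 2-(methoxymethoxy)phenyl on a double-bonded chain carbon bound to a double-bonded chain carbon. Going by the values given here, no measured pair shows what this swap does, and compound 2 at 9600 nM is the only starting point, so the forecast is loose. The expected step is a slight move toward a higher number, within the scatter (a 1.5-fold higher number from compound 2 to compound 3 (0.16 log units; within the scatter)). For compound 3 the estimated value is 14000 nM in this assay (expected range 4000 nM to 50000 nM).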

Compound 3, half-maximal inhibitory concentration: 98000 nM
Compound 3: the middle estimate sits 7.0-fold (0.85 log units) below what was measured, and the stated range ends below it.
By their numbers in this assay, from the lowest: compound 2; then compounds 3 and 1 (each within the scatter of the next).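

The ring at the end of this chain matters: in this assay, 4-fluorophenyl in place of 2-(methoxymethoxy)phenyl on a double-bonded chain carbon bound to a double-bonded chain carbon gives a clear loss (a 10-fold higher number from compound 2 to compound 3 (1.01 log units; beyond the scatter)), so these two rings are not interchangeable here. Compound 3 also cannot be told apart from compound 1, which carries 4-bromophenyl on a saturated chain carbon bound to an oxygen on an aromatic ring in place of 4-(4-fluorophenyl)but-3-en-1-yl (a 1.1-fold lower number from compound 1 to compound 3 (0.04 log units; within the scatter)). Nothing available explains why the ring swap has this effect.

As far as these compounds go, it remains open whether the lower number of compound 2 belongs to the methoxymethoxy group or to the ring carrying it. From the compounds shown here alone, what a hydroxyl group or an amine on that ring would give, or a longer chain, is also open.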